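A few compounds are considered here, and "the series" means these few. Any claim that something is new, unique, unknown or untested is made for them only; others in the source may bear on it.

Measured compounds in an assay on isolated protein for displacement of a labelled ligand from growth hormone secretagogue receptor type 1 (Homo sapiens), with a stated time of 1 h; a higher number here means a weaker inhibitor, a lower number a stronger inhibitor:
compound 1, `COC(=O)C(c1ccccc1)n1nnnc1[C@@H](COCc1ccccc1)NC(=O)C(C)(C)N`: 470 nM
compound 2, `CC(C)(N)C(=O)N[C@H](COCc1ccccc1)c1nnnn1CCCCCNS(C)(=O)=O`: > 5000 nM
compound 3, `CC(C)(N)C(=O)N[C@H](COCc1ccccc1)c1nnnn1CC#N`: 4170 nM

The value of compound 2 is a limit of this assay, not a number (the limit of > 5000 nM in this assay, at which 1 of the 3 values shown sits). Among the two numbers, compound 3 stands highest; its nearest neighbour is compound 1, with an 8.9-fold higher number from compound 1 to compound 3 (0.95 log units; beyond the scatter). The other step on an aromatic nitrogen, an at least 10-fold higher number from compound 1 to compound 2 (1.02 log units; beyond the scatter), runs the same way and is counted as large. Compound 4, `CC(C)(N)C(=O)N[C@H](COCc1ccccc1)c1nnnn1CCC#N`, differs from compound 3 by cyanomethyl in place of cyano on a saturated chain carbon bound to an aromatic nitrogen. For the measured compounds named here, the only step at this same position is an at least 1.1-fold lower number from compound 2 to compound 3 (0.07 log units; that floor lies within the scatter), which stays within the scatter and carries one limit, so it says little. Both substituents that replace the group of compound 1 push the number up, and nothing here separates a short chain from a longer one at this point. Lengthening by one carbon is therefore expected to give no step beyond the scatter in this assay. Compound 4 is estimated at 4500 nM, range 1500 nM to 12000 nM, meaning an expected step of a 1.1-fold higher number from compound 3 to compound 4 (0.03 log units; within the scatter).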

Compound 4, inhibition constant: 2940 nM
The estimate for compound 4 lay 1.5-fold (0.18 log units) above the measured number; the range from low to high includes it.
By their numbers in this assay, from the lowest: compound 1; then compounds 4 and 3 (each within the scatter of the next). At a limit, above all of these: compound 2.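

In this assay, cyanomethyl in place of cyano on a saturated chain carbon bound to an aromatic nitrogen gives a 1.4-fold lower number from compound 3 to compound 4 (0.15 log units; within the scatter), so this extension of the nitrile chain has no readable effect here. The higher number relative to the substituent of compound 1 persists with the extended chain (a 6.3-fold higher number from compound 1 to compound 4 (0.80 log units; beyond the scatter)), so neither nitrile chain matches compound 1 at this aromatic nitrogen. The step of an at least 1.7-fold lower number from compound 2 to compound 4 (0.23 log units; that floor lies within the scatter) rests on a limit and cannot be read, and the same holds for the other steps to the nitrile compounds. Compound 2 carries a limit and not a number: the limit of > 5000 nM in this assay, at which 1 of the 4 values shown sits.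

The substituent of compound 1 combines methoxycarbonyl and benzyl parts, and these compounds do not separate what each part contributes. From the compounds shown here alone, how a benzyl group alone, a carboxylic acid or a longer nitrile chain would read at this place remains open.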